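Compound 3 to compound 4: methoxy replaced by 1-hydroxy-1-methylethyl

This account rests on a few compounds, and the source may have more. Where it says the series, first, only, none or still open, it means among the compounds named here.

For the measured compounds named here, in an assay on HEK293 cells for antagonist activity at P2X purinoceptor 7 (Homo sapiens), read by fluorescence, with a stated time of 2 h (a higher number here means a weaker inhibitor, a lower number a stronger inhibitor), compound 3 `COc1ccc(C(=O)N2CCC(n3cncc3-c3ccc(OS(=O)(=O)c4cccc5cnccc45)cc3)CC2)cc1` gives 77 nM, the lowest of the two numbers measured so far. Compound 1 `CS(=O)(=O)Oc1ccc(-c2cncn2C2CCN(C(=O)c3ccc(Cl)c(C(F)(F)F)c3)CC2)cc1` gives 1570 nM in this assay. Compound 2 `CC(=O)Oc1ccc(-c2cncn2C2CCN(C(=O)c3ccc(Cl)c(C(F)(F)F)c3)CC2)cc1` reaches only a limit in this assay, > 10000 nM, as the limit of > 10000 nM in this assay, at which 1 of the 3 values shown sits, records. Going by the values given here, the single measured step, an at least 6.3-fold higher number from compound 1 to compound 2 (0.80 log units; beyond the scatter), concerns the oxygen-bound group of the shared core and not the carbonyl-bearing aryl, so it gives no direct guidance here. Compound 4 `CC(C)(O)c1ccc(C(=O)N2CCC(n3cncc3-c3ccc(OS(=O)(=O)c4cccc5cnccc45)cc3)CC2)cc1` differs from compound 3 by 1-hydroxy-1-methylethyl in place of methoxy on an aromatic carbon. Among the compounds with values here, no measured step touches this position, so no change beyond the scatter is expected in this assay in either direction. Compound 4 is expected to give 100 nM, between 30 nM and 350 nM. The expected step is a 1.3-fold higher number from compound 3 to compound 4 (0.11 log units; within the scatter).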

Compound 4, half-maximal inhibitory concentration: 109 nM
The estimate for compound 4 lay 1.1-fold (0.04 log units) below the measured number; the range from low to high includes it.
By their numbers in this assay, from the lowest: compounds 3 and 4 (each within the scatter of the next); then compound 1. At a limit, above all of these: compound 2.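

For the compounds shown here, this is the first measured step at this position: in this assay, 1-hydroxy-1-methylethyl in place of methoxy gives a 1.4-fold higher number from compound 3 to compound 4 (0.15 log units; within the scatter). On this aromatic carbon, para to a large group, a larger substituent carrying a hydrogen-bond donor therefore leaves the number within the scatter. Nothing shown bears on the reason for this outcome.

Open, from the compounds shown here alone, is whether an amine or a carboxylic acid on this carbon would also stay within the scatter of compound 3. Going by these compounds, a longer chain ending in hydroxy is equally open.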